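The source may hold more compounds than are shown below. What is called first, only, known or untested is meant among the compounds shown, and "the series" means these compounds.

Measured so far:
compound 1, `COc1cc(N2C(N)=C(C#N)C(c3c(O)ccc4ccccc34)C3=C2CC(C)(C)CC3=O)cc(OC)c1OC`: 2%
compound 2, `COc1cc(N2C(N)=C(C#N)C(c3ccc([N+](=O)[O-])cc3)C3=C2CC(C)(C)CC3=O)cc(OC)c1OC`: 10%

Both values come from a functional assay on Ehrlich cells (Mus musculus) for cytotoxicity, tested at 10 ug/mL; on this read-out higher numbers stand for a stronger effect at the one concentration tested and lower numbers for a weaker effect. Compound 1 stands lowest of the two numbers, with compound 2 as its nearest neighbour, but the step of a number 8 percentage points higher from compound 1 to compound 2 (within the scatter) lies within the scatter, so the two cannot be placed in any order of activity on this assay. That single step is the only one measured, and it exchanges the group on the saturated ring carbon for 4-nitrophenyl.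

The unmeasured compound 3, `COc1cc(N2C(N)=C(C#N)C(c3ccccc3)C3=C2CC(C)(C)CC3=O)cc(OC)c1OC`, differs from compound 1 at the same saturated ring carbon: phenyl in place of 2-hydroxynaphthalen-1-yl on a saturated ring carbon. Going by the values given here, the one measured step at this position, from compound 1 to compound 2, bears on it and was within the scatter. Among the compounds with values here, no step with phenyl itself has been measured, so the expectation rests on that neighbour alone. A step of no size beyond the scatter is therefore expected in this assay, with the estimated step being a number 4 percentage points higher from compound 1 to compound 3 (within the scatter). Compound 3 is estimated at 6%, within a range from 0% to 18%.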

Compound 3, a percentage reported as activity, at one concentration (the size of the read-out at that concentration, not a potency): 0%
Estimate against measurement, compound 3: 6 percentage points above, within the range that was stated.
By their numbers in this assay, from the lowest: compounds 3, 1 and 2 (each within the scatter of the next).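

In this assay, phenyl in place of 2-hydroxynaphthalen-1-yl on the saturated ring carbon gives a number 2 percentage points lower from compound 1 to compound 3 (within the scatter), so giving up the second aromatic ring and the hydrogen-bond donor and acceptor of that group does not separate the two compounds on this read-out. Hydrogen in place of nitro on an aromatic carbon gives a number 10 percentage points lower from compound 2 to compound 3 (within the scatter), which means that the plain phenyl group cannot be told apart from the 4-nitrophenyl group either, and all three groups at this position now stand within the scatter of the next. Nothing at hand explains why these groups read so alike, and no measurement beyond the cell read-out bears on it.

On these data alone, it remains open whether an amine or a carboxylic acid on the phenyl ring, or a non-aromatic group such as cyclohexyl on the saturated ring carbon, would give a number beyond the scatter. As far as these compounds go, it is equally open whether any group at this position would stand apart in a core that carries something other than the 3,4,5-trimethoxyphenyl group, for instance a plain benzyl group, on the ring nitrogen.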